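The compounds below may be only part of what the source reports. "The series", "measured", "known", "first", "only" and "open" are said of these compounds alone.

In a functional assay on A549 cells (Homo sapiens) for antiproliferative activity, read by MTT assay (on this read-out lower numbers stand for stronger inhibition and higher numbers for weaker inhibition), compound 2 `CC1(C)CCc2c(ccc(C(=O)/C=C/c3ccc(OCc4cn(Cc5ccc([N+](=O)[O-])cc5)nn4)cc3)c2O)O1` gives 69900 nM, and compound 1 `CCc1ccccc1-n1cc(COc2ccc(/C=C/C(=O)c3ccc4c(c3O)CCC(C)(C)O4)cc2)nn1` gives 112000 nM, so the two sit within the scatter of each other. Compound 3 `CCCCCn1cc(COc2ccc(/C=C/C(=O)c3ccc4c(c3O)CCC(C)(C)O4)cc2)nn1` carries butyl in place of 4-nitrophenyl on a saturated chain carbon bound to an aromatic nitrogen. Among the compounds with values here, one measured step bears on this, the exchange of 2-ethylphenyl for 4-nitrobenzyl on an aromatic nitrogen: a 1.6-fold lower number from compound 1 to compound 2 (0.20 log units; within the scatter). On that single step, no change beyond the scatter is expected in this assay, and the expected step is a 1.1-fold higher number from compound 2 to compound 3 (0.06 log units; within the scatter). Compound 3 is estimated at 80000 nM, with an expected range of 35000 nM to 170000 nM.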

Compound 3, half-maximal inhibitory concentration: 48600 nM
Compound 3: the middle estimate sits 1.6-fold (0.22 log units) above what was measured; the range from low to high includes it.
By their numbers in this assay, from the lowest: compounds 3, 2 and 1 (each within the scatter of the next, the first and the last beyond it).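

In this assay, a chain without a ring is tolerated at this position: exchanging the 4-nitrophenyl for butyl on a saturated chain carbon bound to an aromatic nitrogen stays within the scatter (a 1.4-fold lower number from compound 2 to compound 3 (0.16 log units; within the scatter)). Against the 2-ethylphenyl group, pentyl gives the first step in the series beyond the scatter, though a modest one (a 2.3-fold lower number from compound 1 to compound 3 (0.36 log units; beyond the scatter)). No evidence on hand accounts for either step.

Going by these compounds, whether a longer chain, or a chain carrying an amine, on that aromatic nitrogen would extend this modest gain remains open.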